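A few compounds are considered here, and "the series" means these few. Any claim that something is new, unique, unknown or untested is made for them only; others in the source may bear on it.

Working notes on the series

Among the compounds with values here, compound 1 `Cn1ccc2cc(Nc3ncc4cc(S(=O)(=O)c5ccc(F)cc5F)c(=O)n(C)c4n3)ccc21` stands lowest of the three numbers so far in a functional assay on K562 cells (Homo sapiens) for inhibition, read by trypan blue exclusion, with a stated time of 72 h; on this read-out lower numbers stand for stronger inhibition and higher numbers for weaker inhibition: compound 1 gives 750 nM. Compound 2 `Cn1c(=O)c(S(=O)(=O)c2ccc(F)cc2F)cc2cnc(Nc3ccc4cccc(O)c4n3)nc21` gives 5000 nM in this assay, and compound 3 `COC(=O)Cn1ccc2cc(Nc3ncc4cc(S(=O)(=O)c5ccc(F)cc5F)c(=O)n(C)c4n3)ccc21` gives 5000 nM in this assay. The two measured steps both lead away from compound 1, a 6.7-fold higher number from compound 1 to compound 2 (0.82 log units; beyond the scatter) and a 6.7-fold higher number from compound 1 to compound 3 (0.82 log units; beyond the scatter), and each is of modest size.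

Compound 4 `Cn1ccc2cc(Nc3ncc4cc(S(=O)(=O)c5ccc(Cl)cc5Cl)c(=O)n(C)c4n3)ccc21` differs from compound 1 in one place: 2,4-dichlorophenyl in place of 2,4-difluorophenyl on a sulfonyl sulfur. Neither measured step touches the (2,4-difluorophenyl)sulfonyl group; one changes the group on the aromatic nitrogen, the other the saturated chain carbon bound to an aromatic nitrogen. No shown step therefore bears on this change, and the data give no direction for it. With the halogen change confined to the sulfonyl-bound ring, no step beyond the scatter is expected in this assay in either direction.

For compound 4 the expected step is no change at the digits printed from compound 1 to compound 4 (within the scatter). Compound 4 is thus estimated at 750 nM in this assay. For compound 4 the expected range runs from 300 nM to 2000 nM.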

Compound 4, half-maximal inhibitory concentration: 750 nM
Compound 4: middle estimate and measured number agree at the digits printed, within the range that was stated.
By their numbers in this assay, from the lowest: compounds 1 and 4 (each within the scatter of the next); then compounds 2 and 3 (each within the scatter of the next).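

At the sulfonyl sulfur, this assay gives no change at the digits printed from compound 1 to compound 4 (within the scatter), so on the core of compound 1 this read-out does not separate 2,4-dichlorophenyl from 2,4-difluorophenyl. Within the data shown here, the earlier steps, a 6.7-fold higher number from compound 1 to compound 2 (0.82 log units; beyond the scatter) and a 6.7-fold higher number from compound 1 to compound 3 (0.82 log units; beyond the scatter), lie at other places and said nothing about this one; this step is the only reading so far at the sulfonyl sulfur. Nothing measured here accounts for the unchanged number.

On these data alone, whether this holds for groups other than these two halogenated phenyl rings remains open, for example an unsubstituted phenyl, a 4-methoxyphenyl or a piperidine-bearing chain on the sulfonyl sulfur. Also open, as far as these compounds go, is how a carboxylic acid in place of the methoxycarbonyl of compound 3 would read.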